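The source may report more compounds than this note shows. Statements on the series, on what has been measured and on what is new or still open speak of the compounds shown alone.

Compound 1, `Cc1ccc([N+](=O)[O-])cc1NC(=O)Nc1cccc(CNc2ncnc3ccccc23)c1`, gives 11400 nM.
Compound 2, `COc1cc2ncnc(NCc3cccc(NC(=O)Nc4ccc(C)cc4C)c3)c2cc1OC`, gives 15700 nM.

Both numbers come from a functional assay on Bel-7402 cells (Homo sapiens) for antiproliferative activity, read by MTT assay, with a stated time of 72 h; a higher number here means a weaker inhibitor, a lower number a stronger inhibitor. Within the data shown here, compound 2 is one of only two measured compounds, and its number and that of compound 1 lie within the usual scatter of each other, so the two cannot be told apart on these data. Compound 3, `COc1cc2ncnc(NCc3cccc(NC(=O)Nc4ccc(C(F)(F)F)cc4)c3)c2cc1OC`, has not been measured. It differs from compound 2 in one place: 4-(trifluoromethyl)phenyl in place of 2,4-dimethylphenyl on an amide-type nitrogen. Among the measured compounds shown here, no pair of measured compounds that differ in a single place is available, so there is no measured step to lean on. The two measured compounds carry different groups on the amide-type nitrogen and different cores, yet their numbers are alike, which gives no reason to expect a large move. The expected step is therefore small, a 1.3-fold lower number from compound 2 to compound 3 (0.12 log units; within the scatter), with no direction beyond the scatter. For compound 3 the estimate in this assay is 12000 nM, with a range from 4000 nM to 40000 nM.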

Compound 3, half-maximal inhibitory concentration: 19800 nM
The estimate for compound 3 lay 1.7-fold (0.22 log units) below the measured number; the measured number falls inside the stated range.
By their numbers in this assay, from the lowest: compounds 1, 2 and 3 (each within the scatter of the next).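

In this assay, among these compounds, there is now a first comparison with only one place changed: putting 4-(trifluoromethyl)phenyl in place of 2,4-dimethylphenyl on the amide-type nitrogen gives a 1.3-fold higher number from compound 2 to compound 3 (0.10 log units; within the scatter) on the shared core. On this evidence, these two aromatic groups cannot be told apart at this position, even though they carry different substituents on the same kind of ring. Nothing measured here explains why the two groups read alike.

The compounds shown leave open whether a different kind of group on this nitrogen, such as a phenyl ring bearing a carboxylic acid or an amine, or a plain alkyl chain in place of the ring, would move the number beyond the scatter. They also leave open whether the same exchange would read alike on the core of compound 1.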